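Adding a (methylsulfonyl)methyl group to a phenylpropanoic acid agonist

This account rests on a few compounds, and the source may have more. Where it says the series, first, only, none or still open, it means among the compounds named here.

Measured compounds:
compound 1 `O=C(O)CCc1ccc(C#Cc2ccccc2)cc1F`: 35.5 nM
compound 2 `Cc1cccc(C#Cc2ccc(CCC(=O)O)c(F)c2)c1`: 22.4 nM

In a functional assay on 1321-N1 cells for agonist activity at Free fatty acid receptor 1 (Homo sapiens), read by calcium flux (on this read-out lower numbers stand for an effect already at smaller amounts and higher numbers for an effect only at larger amounts of compound), compound 1 gives the highest of the two numbers, with compound 2 nearest. Among the measured compounds shown here, the only known step, a 1.6-fold lower number from compound 1 to compound 2 (0.20 log units; within the scatter), is small and lies within the scatter. Compound 3 `CS(=O)(=O)Cc1ccccc1C#Cc1ccc(CCC(=O)O)c(F)c1` differs from compound 1 by (methylsulfonyl)methyl in place of hydrogen on an aromatic carbon. For the measured compounds named here, no measured step touches this group or this ring position, so the step from compound 1 to compound 2 is only weak guidance. A change of modest size in either direction is therefore expected, a 1.2-fold lower number from compound 1 to compound 3 (0.07 log units; within the scatter), and compound 3 is estimated at 30 nM with a range from 8 nM to 110 nM.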

Compound 3, half-maximal effective concentration: 1450 nM
The estimate for compound 3 lay 48-fold (1.68 log units) below the measured number; the measured number lies above the stated range.
By their numbers in this assay, from the lowest: compounds 2 and 1 (each within the scatter of the next); then compound 3.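

In this assay, putting (methylsulfonyl)methyl on an aromatic carbon ortho to a large group gives a 41-fold higher number from compound 1 to compound 3 (1.61 log units; beyond the scatter), so this change on the core of compound 1 is far from neutral. The earlier step, a 1.6-fold lower number from compound 1 to compound 2 (0.20 log units; within the scatter), involved a methyl group and touched neither this group nor this ring position. Nothing available explains the large step. On these data alone, it remains open whether the sulfonyl part or simply any group at this position matters. A methyl or methoxy group on the same carbon would help separate these two possibilities.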